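Cytotoxicity notes on the series: step to compound 4

The source may hold more compounds than are shown below. What is called first, only, known or untested is meant among the compounds shown, and "the series" means these compounds.

Measured in an ADME assay on Huh-7 cells (Homo sapiens) for cytotoxicity; a lower number here means that less compound is tolerated, a higher number that more compound is tolerated:
- compound 1, `NC(=S)Nc1cccc(OCCCCCN2CCN(c3ccc(Cl)c(Cl)c3)C2=O)c1`: 13000 nM
- compound 2, `NC(=S)Nc1cccc(OCCCCCCCNC(=S)Nc2cc(Cl)cc(Cl)c2)c1`: 20000 nM
- compound 3, `NC(=S)Nc1cccc(OCCCCCCCCNC(=S)Nc2cc(Cl)cc(Cl)c2)c1`: 12000 nM

For the measured compounds named here, compound 3 has the lowest of the three numbers in this assay, but its gaps to compound 1 and to compound 2 both lie within the scatter, so the three compounds cannot be ordered on these data; no step between any pair of them is computed here.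

Compound 4, `NC(=S)Nc1cccc(OCCCCCCCCNC(=S)Nc2ccc(Br)cc2)c1`, differs from compound 3 in one place: 4-bromophenyl in place of 3,5-dichlorophenyl on an amide-type nitrogen. The remainder of the molecule, including the eight-carbon chain and the shared core, is unchanged.

With no measured step of this kind in the series, and with all three measured compounds sitting within the scatter of one another, the expected step of a 1.2-fold higher number from compound 3 to compound 4 (0.07 log units; within the scatter) in this assay is none beyond the scatter, in no particular direction. Compound 4 is therefore estimated at 14000 nM in this assay, with a range from 6000 nM to 35000 nM.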

Compound 4, half-maximal cytotoxic concentration: 18000 nM
Estimate against measurement, compound 4: 1.3-fold (0.11 log units) below, and the stated range covers the measured number.
By their numbers in this assay, from the lowest: compounds 3, 1, 4 and 2 (each within the scatter of the next).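

For the compounds shown here, replacing 3,5-dichlorophenyl with 4-bromophenyl on the amide-type nitrogen gives a 1.5-fold higher number from compound 3 to compound 4 (0.18 log units; within the scatter) in this assay, the first single-place reading at this position, and it shows no change beyond the scatter with the eight-carbon chain held fixed. Exchanging the two chlorines for one bromine on the phenyl ring therefore leaves this read-out unmoved within the scatter, though a single step on a single chain supports no wider rule. No supporting data bear on this result.

From the compounds shown here alone, whether an amine or a carboxylic acid on this phenyl ring, or an unsubstituted phenyl, would move the number beyond the scatter remains open. Also open, going by these compounds, is whether the same exchange reads alike on the seven-carbon chain of compound 2 or on a longer chain.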